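The source may report more compounds than this note shows. Statements on the series, on what has been measured and on what is new or still open speak of the compounds shown alone.

Compound 3 `CCOc1cc(NC(=O)C2(NC(=O)c3ccc4c(C5CCCC5)c(-c5ncc(Cl)cn5)n(C)c4c3)CCC2)ccc1/C=C/C(=O)OCC(C)C` carries an isobutyl ester on a cinnamate arm of the shared core. In an ADME assay for pharmacokinetics, in simulated intestinal fluid (on this read-out lower numbers stand for a shorter-lived compound and higher numbers for a longer-lived compound), compound 3 gives > 5 h, which is a limit of the assay rather than a number. Compound 1 `CCOC(=O)/C=C/c1ccc(NC(=O)C2(NC(=O)c3ccc4c(C5CCCC5)c(-c5ncc(Cl)cn5)n(C)c4c3)CCC2)cc1OCC` gives > 5 h, also a limit. Compound 2 `CCCOC(=O)/C=C/c1ccc(NC(=O)C2(NC(=O)c3ccc4c(C5CCCC5)c(-c5ncc(Cl)cn5)n(C)c4c3)CCC2)cc1OCC` likewise gives > 5 h, a limit. The ester steps among these three are therefore all unreadable: a step that the two limits leave unreadable from compound 1 to compound 2, a step that the two limits leave unreadable from compound 1 to compound 3 and a step that the two limits leave unreadable from compound 2 to compound 3, because of the limit of > 5 h in this assay, at which 3 of the 3 values shown sit. Compound 4 `CCOc1cc(NC(=O)C2(NC(=O)c3ccc4c(C5CCCC5)c(-c5ncc(Cl)cn5)n(C)c4c3)CCC2)ccc1/C=C/C(=O)OCc1ccccc1` differs from compound 3 by phenyl in place of isopropyl on a saturated chain carbon bound to an oxygen next to a carbonyl group. Since every ester variant so far reached the limit, compound 4 is expected to show a step that the limit leaves unreadable from compound 3 to compound 4 in this assay, with no readable change. Compound 4 is estimated at 6 h, between 3 h and 12 h.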

Compound 4, half-life: > 5 h
Compound 4 was reported as a limit; the forecaster's own chance of this, stated with the estimate: 75%; the middle value lies beyond the limit too.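

In this assay, going by these compounds alone, compound 4 gives > 5 h and this is a limit, so no step from compound 1, compound 2 or compound 3 to compound 4 can be read: the limit of > 5 h in this assay, at which 4 of the 4 values shown sit. Going by these compounds, how long these four esters actually last, and whether they differ at all, stays open.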